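The source may hold more compounds than are shown below. What is called first, only, known or untested is meant among the compounds shown, and "the series" means these compounds.

Cytotoxicity in this series is read in an ADME assay on Vero cells (Chlorocebus sabaeus) for cytotoxicity; on this read-out lower numbers stand for higher toxicity in this test and higher numbers for lower toxicity in this test. Compound 1 `Oc1ccc(-c2nc3cc(Cl)c(Cl)cc3[nH]2)cc1` gives 18000 nM. Compound 3 `COc1cc(-c2nc3cc(C(F)(F)F)ccc3[nH]2)cc(OC)c1OC` gives 29000 nM. From the compounds shown here alone, compound 2 `COc1cc(OC)cc(-c2nc3cc(C(F)(F)F)ccc3[nH]2)c1` gives only a limit of the assay, > 100000 nM, so that compound 2 sits at the limit of > 100000 nM in this assay, at which 1 of the 3 values shown sits, and its exact number is unknown. Among the compounds with values here, the single measured step touching compound 2 is an at least 3.4-fold lower number from compound 2 to compound 3 (0.53 log units; beyond the scatter), methoxy in place of hydrogen on an aromatic carbon. Compound 4 `COc1cccc(-c2nc3cc(C(F)(F)F)ccc3[nH]2)c1` has not yet been measured; it differs from compound 2 by hydrogen in place of methoxy on an aromatic carbon. Within the data shown here, no measured step removes a methoxy, and the one known step suggests that fewer methoxy groups go with higher numbers, so compound 4 is expected to stay at or near the limit, with a step of about a number no higher from compound 2 to compound 4 (the limit leaves the size open). The estimate for compound 4 is 100000 nM, within 40000 nM to 250000 nM.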

Compound 4, half-maximal cytotoxic concentration: > 100000 nM
Compound 4: a limit, no number; the forecaster's own chance of this, stated with the estimate: 55%; the middle value lies on the limit itself.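

Compound 2 and compound 4 each give only a limit in this assay, so no step between them can be read: the limit of > 100000 nM in this assay, at which 2 of the 4 values shown sit.

The compounds shown leave open whether hydrogen in place of methoxy on an aromatic carbon changes the number at all.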